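This account rests on a few compounds, and the source may have more. Where it says the series, first, only, none or still open, it means among the compounds named here.

Measured so far in a functional assay on cells (Platelet, Homo sapiens) for inhibition; on this read-out higher numbers stand for weaker inhibition and lower numbers for stronger inhibition:
compound 1 `CCOC(=O)c1ccc(-c2nn(C)c3ccccc23)cc1` gives 270 nM
compound 2 `CCCn1nc(-c2ccc(C(=O)OCC)cc2)c2ccccc21` gives 490 nM
compound 3 `COC(=O)c1ccc(-c2nn(Cc3ccccc3)c3ccccc23)cc1` gives 560 nM

Compound 1 and compound 2 share one core and differ by ethyl in place of hydrogen on a saturated chain carbon bound to an aromatic nitrogen; that change makes a 1.8-fold higher number from compound 1 to compound 2 (0.26 log units; within the scatter). Compound 3 carries a core differing from that of compound 1, and this difference is not broken down here; the values of compound 3 and compound 1 stand somewhat apart, whereas compound 3 and compound 2 lie close together.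

Compound 4 `CCCOC(=O)c1ccc(-c2nn(Cc3ccccc3)c3ccccc23)cc1` is not yet measured. It differs from compound 3 by ethyl in place of hydrogen on a saturated chain carbon bound to an oxygen next to a carbonyl group. This is the same kind of change as that between compound 1 and compound 2, though not the same: there the entering ethyl sits on a saturated chain carbon bound to an aromatic nitrogen, here on a saturated chain carbon bound to an oxygen next to a carbonyl group. Within the data shown here, only one earlier step of this kind exists to lean on. In this assay the expected step is a 1.3-fold higher number from compound 3 to compound 4 (0.13 log units; within the scatter), resting on the single earlier case, a 1.8-fold higher number from compound 1 to compound 2 (0.26 log units; within the scatter), with wider allowance since the place differs. Compound 4 is estimated at 750 nM, expected to fall between 300 nM and 1800 nM.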

Compound 4, half-maximal inhibitory concentration: > 10000 nM
Compound 4 gave a limit, no number; the forecaster's own chance of this, stated with the estimate: 3%; middle value at least 13-fold (1.12 log units) from the limit.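

In this assay, from the compounds shown here alone, the change from methoxycarbonyl to propoxycarbonyl gives an at least 17-fold higher number from compound 3 to compound 4 (1.25 log units; beyond the scatter), so ethyl in place of hydrogen does not carry over at one size from one core to the other: the same change on two cores in this assay, a 1.8-fold higher number (0.26 log units; within the scatter) from compound 1 to compound 2 and an at least 17-fold higher number (1.25 log units; beyond the scatter) from compound 3 to compound 4, at least 9.8-fold (0.99 log units) apart, beyond the scatter of two such steps Compound 4 gives > 10000 nM, which is a limit of the assay and not a number, so the true size of the step stays unknown and only its lower bound can be read: the limit of > 10000 nM in this assay, at which 1 of the 4 values shown sits. The comparison rests on a single pair of steps that differ in place as well as in core, since the entering ethyl sits on a saturated chain carbon bound to an aromatic nitrogen in one and on a saturated chain carbon bound to an oxygen next to a carbonyl group in the other, so the gap cannot be assigned to either difference.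

Going by these compounds, it remains open whether ethoxycarbonyl on the core of compound 3 stays close to compound 3 or already approaches compound 4. A carboxylic acid or an amide in place of the ester is also untested among the compounds shown, as is a longer chain on the ester of the core of compound 1.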